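Benzyl in Place of Pyridin-4-ylmethyl on the Chain Amine

A few compounds are considered here, and "the series" means these few. Any claim that something is new, unique, unknown or untested is made for them only; others in the source may bear on it.

In a functional assay on cells for antagonist activity at C-X-C chemokine receptor type 4 (Homo sapiens), read by fluorescence and calcium flux, with stated times of 25 min and 90 s (on this read-out higher numbers stand for weaker inhibition and lower numbers for stronger inhibition), compound 3 `c1ccc2c(c1)CN[C@@H](CN(CCCCNCc1ccncc1)[C@H]1CCCc3cccnc31)C2` gives 22.7 nM, the highest of the two numbers obtained. Its nearest neighbour is compound 2 `c1cncc(CNCCCCN(C[C@H]2Cc3ccccc3CN2)[C@H]2CCCc3cccnc32)c1`, which gives 15.3 nM. The step of a 1.5-fold higher number from compound 2 to compound 3 (0.17 log units; within the scatter) lies within the scatter. Compound 1 `c1ccc(CN(CCCCN(C[C@H]2Cc3ccccc3CN2)[C@H]2CCCc3cccnc32)Cc2ccccc2)cc1` reaches only the limit > 16700 nM in this assay (the limit of > 16700 nM in this assay, at which 1 of the 3 values shown sits). Compound 4 `c1ccc(CNCCCCN(C[C@H]2Cc3ccccc3CN2)[C@H]2CCCc3cccnc32)cc1` differs from compound 3 by phenyl in place of pyridin-4-yl on a saturated chain carbon bound to an amine nitrogen. Among the measured compounds shown here, the only measured step at this position swapped one pyridyl isomer for another and stayed within the scatter, so it gives little guide to removing the ring nitrogen altogether; compound 1 carries two benzyl groups but differs in more than one place. Compound 4 is therefore expected to give about 45 nM (range 10 nM to 250 nM), an estimated step of a 2.0-fold higher number from compound 3 to compound 4 (0.30 log units; within the scatter) that may exceed the scatter.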

Compound 4, half-maximal inhibitory concentration: 20.1 nM
For compound 4 the middle estimate is 2.2-fold (0.35 log units) above the measured one; measured number inside the range.
By their numbers in this assay, from the lowest: compounds 2, 4 and 3 (each within the scatter of the next). At a limit, above all of these: compound 1.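

Phenyl serves here as well as either pyridyl ring, with steps of a 1.1-fold lower number from compound 3 to compound 4 (0.05 log units; within the scatter) and a 1.3-fold higher number from compound 2 to compound 4 (0.12 log units; within the scatter), so among these compounds the ring nitrogen makes no difference beyond the scatter. The large change comes from the amine nitrogen instead: hydrogen in place of benzyl gives an at least 830-fold lower number from compound 1 to compound 4 (2.91 log units; beyond the scatter). That step starts from a limit and not from a number: the limit of > 16700 nM in this assay, at which 1 of the 4 values shown sits.

Still open, going by these compounds, is whether a methyl on that amine nitrogen, in place of hydrogen, would keep these numbers. On these data alone, it is also open whether a carboxylic acid on the phenyl ring or a longer chain would do so.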